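The source may hold more compounds than are shown below. What is called first, only, known or untested is meant among the compounds shown, and "the series" means these compounds.

Measured so far in a functional assay on CHO cells for antagonist activity at metabotropic glutamate receptor 5 (Rattus norvegicus), read by calcium flux; a lower number here means a stronger inhibitor, a higher number a weaker inhibitor:
compound 1 `COc1cccc(-c2cc3nc(C)ccc3cn2)c1` — compound 1 gives 7900 nM
compound 2 `COc1cc(OC)cc(-c2cc3nc(C)ccc3cn2)c1` — compound 2 gives 345 nM

Among the measured compounds shown here, compound 2 stands lowest of the two numbers in this assay; its only neighbour is compound 1, and the step of a 23-fold lower number from compound 1 to compound 2 (1.36 log units; beyond the scatter) is the one measured step in the set. It shows that a substituent at this position of the aryl ring, added as a second methoxy, shifts the read-out strongly.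

Compound 3 `COc1cc(C#N)cc(-c2cc3nc(C)ccc3cn2)c1` is not yet measured. Its difference from compound 2 is cyano in place of methoxy on an aromatic carbon. For the measured compounds named here, no measured step covers a methoxy-to-cyano exchange, so the one step available bears on it only indirectly: the position is clearly responsive, but the direction of exchanging one acceptor group for another is open. A step from compound 2 to compound 3 of modest size is therefore expected, a 1.7-fold lower number from compound 2 to compound 3 (0.24 log units; within the scatter), likely within or just beyond the scatter. For compound 3 the estimate in this assay is 200 nM, with a range from 50 nM to 800 nM.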

Compound 3, half-maximal inhibitory concentration: 6.19 nM
Beside the measured number, compound 3's estimate is 32-fold (1.51 log units) above it; the whole stated range lies above it.
By their numbers in this assay, from the lowest: compound 3; then compound 2; then compound 1.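

In this assay this position responds to which group sits there, not only to whether a group is present: methoxy and cyano count alike in heavy atoms and hydrogen-bond acceptors, yet the exchange gives a 56-fold lower number from compound 2 to compound 3 (1.75 log units; beyond the scatter) here. Set against hydrogen, cyano gives a 1300-fold lower number from compound 1 to compound 3 (3.11 log units; beyond the scatter), so at this position it goes well past what the second methoxy achieved. No measurement at hand accounts for the difference between the two groups.

Going by these compounds, whether the gain is particular to cyano or extends to other groups at this position, such as chlorine, trifluoromethyl or a primary amide, remains open. Every compound shown keeps the first methoxy, so whether the series needs it, or whether a second cyano or a fluorine could take its place, is also unresolved.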